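Chain Substituents on the Core and Interleukin-2 Inhibition

The source may hold more compounds than are shown below. What is called first, only, known or untested is meant among the compounds shown, and "the series" means these compounds.

Compound 1 `Cn1c(Cc2nn(C)c(=O)c3ccccc23)nnc1SCC(=O)Nc1ccc(Cl)cc1Cl`: 7700 nM
Compound 2 `Cn1c(Cc2nn(CCC3OCCO3)c(=O)c3ccccc23)nnc1SCC(=O)Nc1ccc(Cl)cc1Cl`: > 30000 nM, a limit of the assay
Compound 3 `Cn1c(Cc2nn(CCC=O)c(=O)c3ccccc23)nnc1SCC(=O)Nc1ccc(Cl)cc1Cl`: > 30000 nM, a limit of the assay

In an assay on NK92 cells for inhibition of interleukin-2 (Homo sapiens), read by AlphaScreen, with stated times of 30 min and 1 h (a higher number here means a weaker inhibitor, a lower number a stronger inhibitor), compound 3 sits at the limit (the limit of > 30000 nM in this assay, at which 2 of the 3 values shown sit), so only an upper bound on its strength is known. Compound 4 `CN(C)CCCn1nc(Cc2nnc(SCC(=O)Nc3ccc(Cl)cc3Cl)n2C)c2ccccc2c1=O` differs from it by (dimethylamino)methyl in place of formyl on a saturated chain carbon, two bonds along the chain from an aromatic nitrogen. Among the compounds with values here, the steps that bear on this are an at least 3.8-fold higher number from compound 1 to compound 2 (0.59 log units; beyond the scatter) and an at least 3.8-fold higher number from compound 1 to compound 3 (0.59 log units; beyond the scatter): each substituent placed on that chain carbon gave an at least modest loss, while a step that the two limits leave unreadable from compound 2 to compound 3. Compound 4 again carries a substituent there, so compound 4 is expected to remain weak in this assay. The step of an at least 1.2-fold lower number from compound 3 to compound 4 (0.07 log units; that floor lies within the scatter) is therefore expected to be small or not readable. The estimate for compound 4 is 25000 nM, spanning 6000 nM to 100000 nM, with a real chance that only a limit is reported.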

Compound 4, half-maximal inhibitory concentration: > 30000 nM
Compound 4 was reported as a limit (the forecaster's own chance of this, stated with the estimate: 55%); middle value at least 1.2-fold (0.07 log units) away from the limit.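

In this assay, placing 2-(dimethylamino)ethyl on the saturated chain carbon bound to an aromatic nitrogen gives an at least 3.8-fold higher number from compound 1 to compound 4 (0.59 log units; beyond the scatter), so a chain ending in an amine shows a loss as well, alongside the chains of compound 2 and compound 3. The steps among compound 2, compound 3 and compound 4 cannot be read, so these three chains cannot be put in order: the limit of > 30000 nM in this assay, at which 3 of the 4 values shown sit.

From the compounds shown here alone, it remains open whether a plain ethyl or a chain ending in a hydroxyl or a carboxylic acid would keep the strength of compound 1. Going by these compounds, how far each of the three chains lies past the limit also remains open.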